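The source may report more compounds than this note shows. Statements on the series, on what has been measured and on what is new or still open speak of the compounds shown alone.

Two measured compounds share one core. Compound 1 `Cc1c(C(=O)/C=C/c2ccc(Cl)cc2)[n+]([O-])c2ccccc2[n+]1[O-]` gives 38000 nM in a functional assay on HSC-3 cells (Homo sapiens) for cytotoxicity, with a stated time of 48 h (on this read-out higher numbers stand for lower toxicity in this test and lower numbers for higher toxicity in this test), and compound 2 `Cc1c(C(=O)/C=C/c2ccc(Cl)c(Cl)c2)[n+]([O-])c2ccccc2[n+]1[O-]` gives 84000 nM in this assay. Compound 2 thus stands highest of the two numbers, with compound 1 as its nearest neighbour. The step of a 2.2-fold higher number from compound 1 to compound 2 (0.34 log units; beyond the scatter) arose from chloro in place of hydrogen on an aromatic carbon. Compound 3 `Cc1ccc(/C=C/C(=O)c2c(C)[n+]([O-])c3ccccc3[n+]2[O-])cc1` has not yet been measured in this assay. It differs from compound 2 by 4-methylphenyl in place of 3,4-dichlorophenyl on a double-bonded chain carbon bound to a double-bonded chain carbon. Among the compounds with values here, the only measured step that bears on this change is a 2.2-fold higher number from compound 1 to compound 2 (0.34 log units; beyond the scatter), a modest rise that went with one added chloro. Compound 3 loses both chlorines and gains a methyl, so a lower number than that of compound 2 is expected, of roughly the size of that step or somewhat beyond it. Compound 3 is therefore estimated at 30000 nM, within 10000 nM to 90000 nM. The expected step is a 2.8-fold lower number from compound 2 to compound 3 (0.45 log units; beyond the scatter) in this assay.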

Compound 3, half-maximal cytotoxic concentration: 14000 nM
The estimate for compound 3 lay 2.1-fold (0.33 log units) above the measured number; the measured number falls inside the stated range.
By their numbers in this assay, from the lowest: compound 3; then compound 1; then compound 2.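

In this assay, 4-methylphenyl in place of 3,4-dichlorophenyl gave a 6.0-fold lower number from compound 2 to compound 3 (0.78 log units; beyond the scatter), showing that the number can fall at this place on the double-bonded chain as well as rise. The narrower swap of methyl in place of chloro on an aromatic carbon gave a 2.7-fold lower number from compound 1 to compound 3 (0.43 log units; beyond the scatter), so among these three compounds both chloro-bearing compounds stand above the methyl compound, and the single methyl-for-chloro swap already moves the number beyond the scatter. Nothing available explains why these changes move the number in this way.

The compounds shown leave open whether the order follows the presence of chlorine or the presence of the methyl, as no unsubstituted phenyl appears among them. They also leave open where a methoxy group, an amine or a bromo group on this ring would fall.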